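The source may report more compounds than this note shows. Statements on the series, on what has been measured and on what is new or still open speak of the compounds shown alone.

Values in a physicochemical assay, read by spectrophotometry, with a stated time of 30 min (a lower number here means that less compound is needed, a higher number that more compound is needed for the effect), for the measured compounds
compound 1 (`O=C1c2c(O)cc(O)cc2O[C@H](c2cccc(O)c2)[C@H]1O`) gives > 100000 nM (a limit)
compound 2 (`O=C1c2c(O)cc(O)cc2O[C@H](c2c(O)cccc2O)[C@H]1O`) gives > 100000 nM (a limit)

Compound 2 stands at > 100000 nM as a limit of the assay and not a number. The data therefore offer only the limit of > 100000 nM in this assay, at which 2 of the 2 values shown sit, as a guide. Compound 3 (`O=C1c2c(O)cc(O)cc2O[C@H](c2ccccc2O)[C@H]1O`) differs from compound 2 by hydrogen in place of hydroxy on an aromatic carbon with hydrogen in place of hydroxy on an aromatic carbon. Among the measured compounds shown here, no measured pair shows what this change does in this assay so no step beyond the scatter, in either direction, is expected. The estimated step, a step that the limit leaves unreadable from compound 2 to compound 3, stays within that scatter. For compound 3 the expected value is 120000 nM with an estimated range from 50000 nM to 300000 nM and a report of only a limit is likely.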

Compound 3, half-maximal effective concentration: > 100000 nM
Compound 3 was reported as a limit (the forecaster's own chance of this, stated with the estimate: 85%); the middle value does not contradict the limit.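

Compound 3, like compound 1 and compound 2, gives only a limit of the assay in this assay, so no step between compound 3 and either of the others can be read: the limit of > 100000 nM in this assay, at which 3 of the 3 values shown sit.

As far as these compounds go, how moving or removing a hydroxy group changes the concentration needed stays open.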